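The source may report more compounds than this note shows. Statements on the series, on what has been measured and on what is new or still open speak of the compounds shown alone.

In a functional assay on HCT-116 cells (Homo sapiens) for cytotoxicity, read by MTT assay, with a stated time of 72 h (a lower number here means a stronger inhibitor, a higher number a weaker inhibitor), compound 3 , whose structure is `C[C@@H](Nc1c(C(=O)NCc2ccc(F)cc2)nc(Br)c2cccnc12)c1ccccc1`, reports only a limit of the assay and no number, namely > 20000 nM. Compound 1 , with the structure `O=C(NCc1ccc(F)cc1)c1nc(Br)c2cccnc2c1NCc1ccccc1`, likewise reports only a limit, > 20000 nM. Compound 2 , with the structure `Nc1ccc(Nc2c(C(=O)NCc3ccc(F)cc3)nc(Br)c3cccnc23)cc1`, gives 10000 nM. The steps among these three are an at least 2.0-fold lower number from compound 1 to compound 2 (0.30 log units; that floor lies within the scatter), an at least 2.0-fold higher number from compound 2 to compound 3 (0.30 log units; that floor lies within the scatter) and a step that the two limits leave unreadable from compound 1 to compound 3; since two of the three values sit at the limit (the limit of > 20000 nM in this assay, at which 2 of the 3 values shown sit), none of them can be read as a change beyond the usual scatter.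

Compound 4 , with the structure `CNCCCNc1c(C(=O)NCc2ccc(F)cc2)nc(Br)c2cccnc12`, differs from compound 3 by 3-(methylamino)propyl in place of 1-phenylethyl on a nitrogen on an aromatic ring. Going by the values given here, no measured step exchanges an aromatic group on that nitrogen for a chain, so the measured steps offer no direct guide; they show only that benzyl, 4-aminophenyl and 1-phenylethyl on that nitrogen all give weak inhibition. Compound 4 is therefore expected to remain weak, with an expected step of an at least 1.3-fold lower number from compound 3 to compound 4 (0.12 log units; that floor lies within the scatter). The estimate for compound 4 in this assay is 15000 nM, within a range from 5000 nM to 40000 nM.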

Compound 4, half-maximal inhibitory concentration: 9000 nM
The estimate for compound 4 lay 1.7-fold (0.22 log units) above the measured number; low and high end bracket the measured number.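

In this assay, 3-(methylamino)propyl on this nitrogen on an aromatic ring gives the first steps shown that go beyond the scatter: an at least 2.2-fold lower number from compound 3 to compound 4 (0.34 log units; beyond the scatter), and an at least 2.2-fold lower number from compound 1 to compound 4 (0.34 log units; beyond the scatter). Set against the 4-aminophenyl group, the chain brings no change, with a 1.1-fold lower number from compound 2 to compound 4 (0.05 log units; within the scatter), so a group with no ring can stand on this nitrogen and read level with the aromatic one. The two larger steps give only minimum sizes, because compound 1 and compound 3 each stand at a limit of the assay and not at a number: the limit of > 20000 nM in this assay, at which 2 of the 4 values shown sit.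

As far as these compounds go, it remains open whether a plain butyl chain, with no amine in it, would read the same, so the part played by the chain's amine cannot be told. How a longer chain or a dimethylamino end would read in this assay is open as well.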